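Piperidinylcarbonyl for methoxymethylcarbonyl at the ring amide

This account rests on a few compounds, and the source may have more. Where it says the series, first, only, none or still open, it means among the compounds named here.

Compound 3 `COCC(=O)N1CCC(NS(=O)(=O)c2ccc(NC(=O)c3ccccc3C)c3ccccc23)CC1` gives 15.8 nM in an assay on L1.2 cells for binding affinity to C-C chemokine receptor type 8 (Homo sapiens) (on this read-out lower numbers stand for stronger inhibition and higher numbers for weaker inhibition), the lowest of the two numbers in the series. Compound 2 `O=C(Nc1ccc(S(=O)(=O)N2CCOCC2)c2ccccc12)c1ccccc1` gives 7750 nM in this assay. Compound 1 `O=C(Nc1ccc(S(=O)(=O)N2CCCCC2)c2ccccc12)c1ccccc1` reaches only a limit of > 30000 nM in this assay, not a number (the limit of > 30000 nM in this assay, at which 1 of the 3 values shown sits). Going by the values given here, the single measured step, an at least 3.8-fold lower number from compound 1 to compound 2 (0.58 log units; beyond the scatter), places morpholin-4-yl in place of piperidin-1-yl on a sulfonyl sulfur.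

Compound 4 `Cc1ccccc1C(=O)Nc1ccc(S(=O)(=O)NC2CCN(C(=O)N3CCCCC3)CC2)c2ccccc12` differs from compound 3 in one place: piperidin-1-yl in place of methoxymethyl on a carbonyl carbon. Among the compounds with values here, the change sits on a carbonyl carbon whose other neighbour is an amide-type nitrogen in a ring, so the measured step from compound 1 to compound 2, which concerns a sulfonyl sulfur and a different pair of groups, does not bear on it directly; it shows only that a piperidin-1-yl ring can be exchanged for a heteroatom-bearing alternative with an effect beyond the scatter at another site. Within the data shown here, no measured step compares methoxymethyl with piperidin-1-yl on a carbonyl carbon. The expectation for compound 4 is therefore a step of a 1.6-fold higher number from compound 3 to compound 4 (0.20 log units; within the scatter) in this assay, within or close to the scatter, with no clear direction. Compound 4 is estimated at 25 nM in this assay, between 6 nM and 100 nM.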

Compound 4, inhibition constant: 4.2 nM
Compound 4: the middle estimate sits 6.0-fold (0.77 log units) above what was measured; the whole stated range lies above it.
By their numbers in this assay, from the lowest: compound 4; then compound 3; then compound 2. At a limit, above all of these: compound 1.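

In this assay, going by these compounds alone, piperidin-1-yl in place of methoxymethyl on a carbonyl carbon whose other neighbour is an amide-type nitrogen in a ring gives the only measured step at this position (a 3.8-fold lower number from compound 3 to compound 4 (0.58 log units; beyond the scatter)). The position thus accepts one six-membered non-aromatic ring, with 6 heavy atoms in place of 3 and no hydrogen-bond acceptor in place of 1, and the number falls rather than rises, which compound 1 and compound 2 could not show, as they carry neither group at this place. Nothing measured in this set bears on why the number falls with this change.

On these data alone, it remains open whether the ring itself matters or only the heavy-atom count, and an open-chain amine such as diethylamino or a longer ether chain on the same carbonyl carbon would separate the two readings. Within the data shown here, also open is whether the step carries over to a core other than the one shared by compound 3 and compound 4, as this pair gives a single reading in this assay.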